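Fluoro Step Repeated on the Benzylated Core

The source may hold more compounds than are shown below. What is called first, only, known or untested is meant among the compounds shown, and "the series" means these compounds.

Compound 1 `c1ccc(Sc2ncnc3[nH]cnc23)cc1` gives 0% in an assay on isolated protein for inhibition of RAC-alpha serine/threonine-protein kinase (Homo sapiens), tested at 30 uM; a higher number here means more inhibition at the concentration tested (going by the name of the read-out), a lower number less inhibition. Compound 2 `Fc1ccc(Sc2ncnc3[nH]cnc23)cc1` carries fluoro in place of hydrogen on an aromatic carbon; in this assay compound 2 gives 0%, the step being no change at the digits printed from compound 1 to compound 2 (within the scatter). Compound 3 `c1ccc(Cn2cnc3c(Sc4ccccc4)ncnc32)cc1` differs from compound 1 by benzyl in place of hydrogen on an aromatic nitrogen; in this assay compound 3 gives 1%, a step of a number 1 percentage points higher from compound 1 to compound 3 (within the scatter). All three numbers lie within the scatter of one another, so no order among them can be read.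

Compound 4 `Fc1ccc(Cn2cnc3c(Sc4ccccc4)ncnc32)cc1` carries fluoro in place of hydrogen on an aromatic carbon, the same change that separates compound 1 from compound 2, and the place is described in identical words for both pairs. In this assay the expected step is a number 1 percentage points lower from compound 3 to compound 4 (within the scatter). This rests on compound 3 at 1% and on the earlier step of no change at the digits printed from compound 1 to compound 2 (within the scatter). Compound 4 is therefore expected to give 0% in this assay.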

Compound 4, a percentage reported as inhibition, at one concentration (the size of the read-out at that concentration, not a potency): 13%
Estimate against measurement, compound 4: 13 percentage points below; measured number outside the range, above it.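

In this assay, the fluoro change gives a number 12 percentage points higher from compound 3 to compound 4 (beyond the scatter), yet the steps on the two cores cannot be told apart: the same change on two cores in this assay, no change at the digits printed (within the scatter) from compound 1 to compound 2 and a number 12 percentage points higher (beyond the scatter) from compound 3 to compound 4, 12 percentage points apart, within the scatter of two such steps.

This does not show that the change behaves differently on the benzylated core, nor that it carries over unchanged: each core offers a single pair, and the fluoro stands on different groups, 4-fluorophenyl in compound 2 and 4-fluorobenzyl in compound 4. The full replacement of hydrogen by 4-fluorobenzyl gives a number 13 percentage points higher from compound 1 to compound 4 (beyond the scatter), a modest step.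

Still open, going by these compounds, is whether the fluoro step would repeat on a further pair. Also open, on these data alone, is how an amine or a carboxylic acid on the benzyl ring, or a longer chain in its place, would read.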